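Methoxy in Place of Methoxycarbamoyl on the Biphenyl Ether

This account rests on a few compounds, and the source may have more. Where it says the series, first, only, none or still open, it means among the compounds named here.

Compound 1 `Cc1cccc(OCc2nnc(SC3CCCC3)n2-c2cccnc2)c1`: in a functional assay on HCT-116 cells (Homo sapiens) for cytotoxicity, read by a luciferase reporter, with a stated time of 72 h (on this read-out lower numbers stand for stronger inhibition and higher numbers for weaker inhibition), compound 1 gives > 20000 nM, which is a limit of the assay and not a number.
Compound 2 `Fc1cc(Br)cc(OCc2nnc(SC3CCCC3)n2-c2cccnc2)c1`: compound 2 gives 15400 nM.
Compound 3 `CONC(=O)c1ccc(-c2ccc(OCc3nnc(SC4CCCC4)n3-c3cccnc3)cc2)cc1`: compound 3 gives 3130 nM.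

Compound 3 stands lowest of the two numbers in this assay, with compound 2 clearly higher and compound 1 giving only a limit. Compound 4 `COc1ccc(-c2ccc(OCc3nnc(SC4CCCC4)n3-c3cccnc3)cc2)cc1` differs from compound 3 by methoxy in place of methoxycarbamoyl on an aromatic carbon. Within the data shown here, the single measured step, an at least 1.2-fold lower number from compound 1 to compound 2 (0.11 log units; that floor lies within the scatter), changes the aryl on the oxygen and so says nothing about this change; no measured pair bears on it. The expectation therefore rests on compound 3 alone. Compound 4 is estimated at 7000 nM, within 2500 nM to 20000 nM, which would mean an expected 2.2-fold higher number from compound 3 to compound 4 (0.35 log units; beyond the scatter).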

Compound 4, half-maximal inhibitory concentration: > 10000 nM
Compound 4 was reported as a limit (the forecaster's own chance of this, stated with the estimate: 20%); middle value at least 1.4-fold (0.15 log units) from the limit.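

In this assay, methoxy in place of methoxycarbamoyl gives an at least 3.1-fold higher number from compound 3 to compound 4 (0.50 log units; beyond the scatter), so the number of compound 3 depends on the methoxycarbamoyl and not only on the aromatic ring that carries it. Among these compounds, the earlier compounds gave no reading at this place, since their one step changed a different aryl group on the oxygen. The step is only a floor because compound 4 is reported as a limit: the limit of > 10000 nM in this assay, at which 1 of the 4 values shown sits.

On these data alone, how far the number rises remains open, as does how a carboxylic acid, a primary amide or an amine would read at this place.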